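Swapping a Methylphenyl for a Dimethoxyphenyl

The compounds below may be only part of what the source reports. "The series", "measured", "known", "first", "only" and "open" are said of these compounds alone.

Compound 2 `COc1cc2c(Oc3ccc(NC(=O)c4cc(-c5ccc(C)cc5)ccn4)cc3F)ccnc2cc1OCCCN1CCCC1` was tested in a functional assay on MKN-45 cells (Homo sapiens) for cytotoxicity, read by MTT assay, with a stated time of 72 h (a higher number here means a weaker inhibitor, a lower number a stronger inhibitor), where compound 2 gives 440 nM. Compound 1 `COc1cc2c(Oc3ccc(NC(=O)c4cc(-c5ccccc5F)ccn4)cc3F)ccnc2cc1OCCCN1CCCCC1` gives 180 nM in this assay, so compound 2 stands as the higher of the two numbers, a gap beyond the usual scatter. Compound 3 `COc1ccc(-c2ccnc(C(=O)Nc3ccc(Oc4ccnc5cc(OCCCN6CCCC6)c(OC)cc45)c(F)c3)c2)c(OC)c1` is not yet measured. It differs from compound 2 in one place: 2,4-dimethoxyphenyl in place of 4-methylphenyl on an aromatic carbon. For the measured compounds named here, no measured pair shows this kind of change, so the step is uncertain and is expected to stay within the scatter. For compound 3 the estimated value is 400 nM, with a range from 150 nM to 1200 nM. That estimate means an expected step of a 1.1-fold lower number from compound 2 to compound 3 (0.04 log units; within the scatter).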

Compound 3, half-maximal inhibitory concentration: 740 nM
The estimate for compound 3 lay 1.9-fold (0.27 log units) below the measured number; low and high end bracket the measured number.
By their numbers in this assay, from the lowest: compound 1; then compounds 2 and 3 (each within the scatter of the next).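

In this assay the swap gives a 1.7-fold higher number from compound 2 to compound 3 (0.23 log units; within the scatter) and so this position, opposite the ring nitrogen, accepts 2,4-dimethoxyphenyl in place of 4-methylphenyl with no change that stands clear of the scatter. For the compounds shown here, this is the first one-place comparison, and it shows that adding heavy atoms and hydrogen-bond acceptors to this aryl group need not move the number measurably. Nothing measured here bears on why this is so. From the compounds shown here alone, whether a 4-methoxyphenyl group, an amine or a carboxylic acid at this position would shift the number beyond the scatter remains open.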